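The source may report more compounds than this note shows. Statements on the series, on what has been measured and on what is new or still open speak of the compounds shown alone.

Measured compounds:
- Compound 1, `COc1cc(C)cc(-c2c(-c3ccnc(-c4ccc(C(C)=O)cc4)c3)cnn2CC#N)c1`: 106%
- Compound 2, `COc1cc(C)cc(-c2nn(CC#N)cc2-c2ccc(-c3cccc(C(C)=O)c3)nc2)c1`: 104%
- Compound 3, `Cc1cc(O)cc(-c2nn(CC#N)cc2-c2ccnc(-c3ccc(Oc4ccccc4)cc3)c2)c1`: 103%

All three were run in a functional assay on OVCAR-3 cells (Homo sapiens) for cytotoxicity, read by sulforhodamine B assay, with a stated time of 48 h, tested at 0.01 uM; a higher number here means a weaker effect of the compound at the concentration tested, a lower number a stronger effect. Compound 3 gives the lowest of the three numbers, but its nearest neighbour is compound 2 and its furthest is compound 1, and both gaps stay within the scatter of repeated measurements, so the three compounds cannot be told apart on these data. Among the measured compounds shown here, no pair among them differs in only one place, so no single-point step is available to guide an expectation.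

Compound 4, `Cc1cc(O)cc(-c2nn(CC#N)cc2-c2ccnc(-c3ccc(N(C)C)cc3)c2)c1`, has not yet been measured. It differs from compound 3 in one spot: dimethylamino in place of phenoxy on an aromatic carbon.

Since compound 3 already sits at 103% and the other two compounds cluster alongside it in this assay, there is no basis for expecting a change beyond the scatter; the expected step is no change at the digits printed from compound 3 to compound 4 (within the scatter). Compound 4 is therefore estimated at 103%, with an expected range from 94% to 112%.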

Compound 4, a percentage reported as activity, at one concentration (the size of the read-out at that concentration, not a potency): 91%
For compound 4 the middle estimate is 12 percentage points above the measured one; measured number below the stated range.
By their numbers in this assay, from the lowest: compound 4; then compounds 3, 2 and 1 (each within the scatter of the next).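

In this assay, among the compounds shown here, dimethylamino in place of phenoxy gives a number 12 percentage points lower from compound 3 to compound 4 (beyond the scatter) and so provides the only single-place step in this set. For the compounds shown here, it shows that the read-out responds to what sits on this aromatic carbon, para to a large group, even though the earlier compounds could not be told apart. The step is modest, and it is a read-out at one concentration rather than a potency. No measurement here explains the step.

Because phenoxy gives way to a group with no ring and with nitrogen in place of oxygen, the compounds shown cannot separate the loss of the ring from the change of atom. Methoxy, a primary amine or morpholine on the same carbon would bear on that question.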